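This account rests on a few compounds, and the source may have more. Where it says the series, first, only, none or still open, it means among the compounds named here.

Working notes on the series. Two compounds have numbers in an assay on isolated protein for binding affinity to melanin-concentrating hormone receptor 1 (Homo sapiens); a higher number here means a weaker inhibitor, a lower number a stronger inhibitor. Compound 1 `CO[C@@H]1CN(CC2Cc3ccccc3C2)CC[C@H]1n1c(C)nc2cc(C)ccc21` gives 47 nM in this assay. Compound 2 `CO[C@@H]1CN(C[C@H]2Cc3ccc(C#N)cc3C2)CC[C@H]1n1c(C(C)(C)O)nc2cc(C)c(F)cc21` gives 0.5 nM in this assay, the lowest of the two numbers; its gap to compound 1 lies beyond the scatter, though the two structures differ in several places at once and no single step can be read from them.

Compound 3 `CO[C@@H]1CN(C[C@H]2Cc3ccc(C#N)cc3C2)CC[C@H]1n1c(C(C)(C)O)nc2cc(C)ccc21` has not been measured in this assay. It differs from compound 2 in one place: hydrogen in place of fluoro on an aromatic carbon, the position being ortho to a methyl group, meta to a fused ring and para to a fused ring. Among the compounds with values here, no measured pair isolates this change, so its effect is unknown from the data. A small step is expected from compound 2 to compound 3, a 2.0-fold higher number from compound 2 to compound 3 (0.30 log units; within the scatter), most likely towards a higher number but possibly none beyond the scatter. Compound 3 is thus estimated at 1 nM in this assay, with a range from 0.4 nM to 2.5 nM.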

Compound 3, inhibition constant: 3 nM
Compound 3: the middle estimate sits 3.0-fold (0.48 log units) below what was measured, outside the stated range (above it).
By their numbers in this assay, from the lowest: compound 2; then compound 3; then compound 1.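

In this assay, hydrogen in place of fluoro on an aromatic carbon, ortho to a methyl group, gives a 6.0-fold higher number from compound 2 to compound 3 (0.78 log units; beyond the scatter) with everything else held constant. Within the data shown here, this is the first single-place comparison, and it shows that the fluoro at this position makes a real, if modest, difference to the number, one that lies beyond the scatter. Nothing available explains this step.

Going by these compounds, only hydrogen and fluoro have been compared at this position, so it remains open whether a chloro or a trifluoromethyl group would give a lower number than hydrogen, or whether a larger group such as a phenyl ring would be accepted at all. On these data alone, it is also open whether the step would keep its size with a different group elsewhere on the shared core.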